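Aldehyde in place of dimethylamine on the side chain

This account rests on a few compounds, and the source may have more. Where it says the series, first, only, none or still open, it means among the compounds named here.

Measured so far:
compound 1 `Cn1nc(Cc2nnc(SCCCCCCCC(=O)Nc3ccc(Cl)cc3Cl)n2CCCO)c2ccccc2c1=O` gives > 30000 nM in an assay on 32D cells for inhibition of interleukin-15 (Mus musculus), read by resazurin assay, with stated times of 30 min and 2.5 days, in the presence of a further agent that is not named here (a higher number here means a weaker inhibitor, a lower number a stronger inhibitor), a limit of the assay and not a number.
compound 2 `CN(C)CCCn1nc(Cc2nnc(SCCCCCCCC(=O)Nc3ccc(Cl)cc3Cl)n2C)c2ccccc2c1=O` gives 2300 nM in this assay.

Among the compounds with values here, compound 2 is the only compound of the pair with a numerical value; for compound 1 only the limit of > 30000 nM in this assay, at which 1 of the 2 values shown sits, is recorded, so no step between compound 1 and compound 2 can be sized beyond saying that compound 2 is measurably active and compound 1 is not within the range tested. The two compounds differ at more than one place, so their comparison says nothing about any single change.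

Compound 3 `Cn1c(Cc2nn(CCC=O)c(=O)c3ccccc23)nnc1SCCCCCCCC(=O)Nc1ccc(Cl)cc1Cl` is drawn from compound 2 by one change: formyl in place of (dimethylamino)methyl on a saturated chain carbon, two bonds along the chain from an aromatic nitrogen. Within the data shown here, no measured step of this kind exists, so the size of the effect is open. The expectation is a loss, with compound 3 estimated at 8000 nM (range 2500 nM to 30000 nM), the step from compound 2 to compound 3 expected to be a 3.5-fold higher number from compound 2 to compound 3 (0.54 log units; beyond the scatter), with a real chance that only a limit is returned.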

Compound 3, half-maximal inhibitory concentration: 8900 nM
Estimate against measurement, compound 3: 1.1-fold (0.05 log units) below; low and high end bracket the measured number.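

Within the data shown here, at the saturated chain carbon two bonds along the chain from an aromatic nitrogen, formyl in place of (dimethylamino)methyl gives a 3.9-fold higher number from compound 2 to compound 3 (0.59 log units; beyond the scatter) in this assay, a modest loss and the first step that can be sized for a single change. The earlier pair differs in more than one place and could not isolate this side chain, whereas this comparison shows that measurable activity persists without the dimethylamino group, with compound 3 at 8900 nM in this assay. Among these compounds, nothing measured so far bears on why the step has this size.

A single step cannot separate the effect of removing the dimethylamino group from that of introducing the formyl group, so it remains open which of the two accounts for the loss. A carboxylic acid, a primary amine or a morpholine at the end of the same chain, together with a longer or shorter chain carrying the dimethylamino group, would show whether the terminal group or the chain length matters more at this position.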